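Chloro in Place of Cyano on the Terminal Aryl Ring

The source may hold more compounds than are shown below. What is called first, only, known or untested is meant among the compounds shown, and "the series" means these compounds.

compound 1 `COc1cc(/C=C/c2ccc(NC(=O)/C=C/c3cc(OC)c(OC)c(OC)c3)cc2)cc(OC)c1`: 1820 nM
compound 2 `COc1cc(/C=C/c2ccc(NC(=O)/C=C/c3cc(OC)c(O)c(OC)c3)cc2)cc(OC)c1`: 3080 nM
compound 3 `COc1cc(/C=C/c2ccc(NC(=O)/C=C/c3ccc(C#N)cc3)cc2)cc(OC)c1`: 3320 nM

In a functional assay on HT-29 cells (Homo sapiens) for inhibition, read by MTT assay, with a stated time of 48 h (on this read-out higher numbers stand for weaker inhibition and lower numbers for stronger inhibition), compound 3 gives 3320 nM, the highest of the three numbers. The step of a 1.1-fold higher number from compound 2 to compound 3 (0.03 log units; within the scatter) is within the scatter, and the two values of compound 1 and compound 3 are likewise within the scatter, so the three compounds cannot be ranked. Compound 4 `COc1cc(/C=C/c2ccc(NC(=O)/C=C/c3ccc(Cl)cc3)cc2)cc(OC)c1` differs from compound 3 by chloro in place of cyano on an aromatic carbon. For the measured compounds named here, no measured step tests this exchange: the step of a 1.7-fold higher number from compound 1 to compound 2 (0.23 log units; within the scatter) and the step of a 1.1-fold higher number from compound 2 to compound 3 (0.03 log units; within the scatter) are both within the scatter and touch other groups. For compound 4 no step beyond the scatter is therefore expected, with a 1.0-fold lower number from compound 3 to compound 4 (0.00 log units; within the scatter). Compound 4 is estimated at 3300 nM, between 1500 nM and 7500 nM.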

Compound 4, half-maximal inhibitory concentration: 10300 nM
The estimate for compound 4 lay 3.1-fold (0.49 log units) below the measured number; the whole stated range lies below it.
By their numbers in this assay, from the lowest: compounds 1, 2 and 3 (each within the scatter of the next); then compound 4.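

In this assay, for the compounds shown here, chloro in place of cyano on the aromatic carbon para to a large group gives a 3.1-fold higher number from compound 3 to compound 4 (0.49 log units; beyond the scatter) and lies beyond the scatter, which no earlier step did, so the group at this position does matter. The exchange of 4-hydroxy-3,5-dimethoxyphenyl for 4-chlorophenyl likewise gives a 3.3-fold higher number from compound 2 to compound 4 (0.52 log units; beyond the scatter), although 4-cyanophenyl in that place stayed within the scatter. No available evidence bears on this difference.

Going by these compounds, whether an amine, a carboxylic acid or bromo at this position would stay near compound 3 or near compound 4 remains open.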